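Amide variation on the glycosylated pyrimidinone series

The source may report more compounds than this note shows. Statements on the series, on what has been measured and on what is new or still open speak of the compounds shown alone.

Measured so far:
compound 1 `CC(C)CCC(=O)Nc1ccn([C@H]2CC[C@H](O[C@H]3O[C@H](C)[C@@H](N(C)C)[C@H](O)[C@H]3O)[C@@H](C)O2)c(=O)n1` — 390 nM
compound 2 `CC(C)=CC(=O)Nc1ccn([C@H]2C[C@@H](O)[C@H](O)[C@@H](C)O2)c(=O)n1` — > 20000 nM

Going by the values given here, in a functional assay on HCT-116 cells (Homo sapiens) for cytotoxicity, read by sulforhodamine B assay, with a stated time of 24 h (a higher number here means a weaker inhibitor, a lower number a stronger inhibitor), compound 1 gives 390 nM, the only numerical value in hand. Compound 2 in this assay is reported only as a limit, > 20000 nM, which is the limit of > 20000 nM in this assay, at which 1 of the 2 values shown sits, and not a number. Compound 3 `C/C=C(\C)C(=O)Nc1ccn([C@H]2CC[C@H](O[C@H]3O[C@H](C)[C@@H](N(C)C)[C@H](O)[C@H]3O)[C@@H](C)O2)c(=O)n1` is not yet measured; it differs from compound 1 by 1-methylprop-1-en-1-yl in place of isopentyl on a carbonyl carbon. Among the compounds with values here, with no measured step to guide the size, the expected step of a 1.3-fold higher number from compound 1 to compound 3 (0.11 log units; within the scatter) is small, likely within the scatter. Compound 3 is estimated at 500 nM, ranging from 150 nM to 2000 nM.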

Compound 3, half-maximal inhibitory concentration: 6450 nM
For compound 3 the middle estimate is 13-fold (1.11 log units) below the measured one; measured number outside the range, above it.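

In this assay, replacing isopentyl with 1-methylprop-1-en-1-yl on a carbonyl carbon gives a 17-fold higher number from compound 1 to compound 3 (1.22 log units; beyond the scatter). The rest of the structure is shared, so this single position can move the read-out beyond the scatter, and similar-looking small carbon groups are not interchangeable here. Nothing in the data at hand accounts for the size of this step.

On these data alone, it remains open whether the double bond or the shape of the chain carries the step. Also open, as far as these compounds go, is how a saturated sec-butyl group, a longer chain or a chain ending in an amine would read on the same carbonyl carbon.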